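Removing a sugar from a phloretin-based thiol linker

A few compounds are considered here, and "the series" means these few. Any claim that something is new, unique, unknown or untested is made for them only; others in the source may bear on it.

This small set concerns cytotoxicity towards a human colon cancer cell line, measured in a functional assay on HT-29 cells (Homo sapiens) for cytotoxicity, read by sulforhodamine B assay, with a stated time of 48 h; a higher number here means a weaker inhibitor, a lower number a stronger inhibitor. Compound 1, `O=C(CCCCCN1C(=O)CC(SCCOCCOCCOc2cc(O)c(C(=O)CCc3ccc(O)cc3)c(O[C@@H]3O[C@H](CO)[C@@H](O)[C@H](O)[C@H]3O)c2)C1=O)OCn1cc(F)c(=O)[nH]c1=O`, carries a sugar on its aromatic core and is joined through a linker to an anticancer payload. In this assay compound 1 gives > 100000 nM, which is a limit of the assay rather than a number. Compound 2, `O=C(CCCCCN1C(=O)CC(SCCOCCOCCOc2cc(O)c(C(=O)CCc3ccc(O)cc3)c(O)c2)C1=O)OCn1cc(F)c(=O)[nH]c1=O`, is the same molecule with the sugar removed, the change being (hydrogen in place of 3,4,5-trihydroxy-6-(hydroxymethyl)oxan-2-yl on an oxygen on an aromatic ring). In this assay compound 2 gives 43700 nM. That amounts to an at least 2.2-fold lower number from compound 1 to compound 2 (0.35 log units; beyond the scatter), a step whose size is bounded only on one side, because compound 1 sits at the limit of > 100000 nM in this assay, at which 2 of the 3 values shown sit.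

Compound 3, `O=C(CCc1ccc(O)cc1)c1c(O)cc(OCCOCCOCCS)cc1O[C@@H]1O[C@H](CO)[C@@H](O)[C@H](O)[C@H]1O`, keeps the sugar but ends in a free thiol and carries no payload. How its core differs from that of compound 1 is not broken down here. In this assay compound 3 gives > 100000 nM, again a limit of the assay. Compound 4, `O=C(CCc1ccc(O)cc1)c1c(O)cc(OCCOCCOCCS)cc1O`, is not yet measured; it differs from compound 3 by hydrogen in place of 3,4,5-trihydroxy-6-(hydroxymethyl)oxan-2-yl on an oxygen on an aromatic ring, the same change as between compound 1 and compound 2, at the same place.

On that basis compound 4 is expected to follow the earlier step in direction, giving an estimated at least 1.1-fold lower number from compound 3 to compound 4 (0.04 log units; that floor lies within the scatter). Since compound 3 sits at the limit of > 100000 nM in this assay, at which 2 of the 3 values shown sit, only a partial picture of that step can be drawn. The estimated value for compound 4 is 90000 nM, between 30000 nM and 300000 nM.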

Compound 4, half-maximal inhibitory concentration: 29100 nM
Beside the measured number, compound 4's estimate is 3.1-fold (0.49 log units) above it; measured number outside the range, below it.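

The second core repeats what the first one showed: in this assay, replacing the 3,4,5-trihydroxy-6-(hydroxymethyl)oxan-2-yl group on the oxygen with hydrogen gives an at least 3.4-fold lower number from compound 3 to compound 4 (0.53 log units; beyond the scatter), so the number falls in the same direction on both cores, one with the payload and one ending in a free thiol. Compound 3 gives > 100000 nM, which is a limit of the assay and not a number, so this step has a floor but no known upper size. The pair of steps therefore shows that the direction carries from one core to the other, but it does not show that the change is worth the same amount on each core: the same change on two cores in this assay, an at least 2.2-fold lower number (0.35 log units; beyond the scatter) from compound 1 to compound 2 and an at least 3.4-fold lower number (0.53 log units; beyond the scatter) from compound 3 to compound 4; the limit leaves it open whether they differ.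

The compounds shown leave open what other groups would do on that same oxygen, for instance a small methyl group, a longer chain or a chain ending in an amine or a carboxylic acid. They also leave open how much of the change comes from losing the sugar as a whole rather than any one part of it, and a sugar-bearing compound with a value inside the assay's range would be needed to fix the size of either step.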